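A few compounds are considered here, and "the series" means these few. Any claim that something is new, unique, unknown or untested is made for them only; others in the source may bear on it.

Compound 2 `Cc1nc(-c2ccccc2F)c(C(=O)N2CCN(c3cc(Cl)cc(Cl)c3)CC2)o1` is tested in a functional assay on HL-60 cells (Homo sapiens) for inhibition, read by MTT assay, with a stated time of 72 h (on this read-out lower numbers stand for stronger inhibition and higher numbers for weaker inhibition), where it gives 60.2 nM. Among the three measured compounds, compound 1 `Cc1nc(-c2ccccc2F)c(C(=O)N2CCN(c3cccc(Cl)c3)CC2)o1` gives 39.4 nM, a number within the scatter of compound 2, while compound 3 `Cc1ccc(C)c(N2CCN(C(=O)c3oc(C)nc3-c3ccc(F)cc3)CC2)c1` gives 358 nM, a higher number that lies beyond it. Among the measured compounds shown here, the only single change measured, a 1.5-fold higher number from compound 1 to compound 2 (0.18 log units; within the scatter), adds a second chloro to the ring on the piperazine nitrogen and barely moves the read-out. Compound 4 `COc1cccc(N2CCN(C(=O)c3oc(C)nc3-c3ccccc3F)CC2)c1` differs from compound 2 by 3-methoxyphenyl in place of 3,5-dichlorophenyl on an amine nitrogen in a ring, and compound 3 does not bear on it, since it differs in more than one place. This change replaces both chlorines rather than adding one, so a weaker result is expected, about a 1.8-fold higher number from compound 2 to compound 4 (0.26 log units; within the scatter). Compound 4 is estimated at 110 nM, within 35 nM to 400 nM.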

Compound 4, half-maximal inhibitory concentration: 56.1 nM
Compound 4: middle estimate off by 2.0-fold (0.29 log units), on the high side, and the stated range covers the measured number.
By their numbers in this assay, from the lowest: compounds 1, 4 and 2 (each within the scatter of the next); then compound 3.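

In this assay the change from 3,5-dichlorophenyl to 3-methoxyphenyl on the amine nitrogen in a ring gives a 1.1-fold lower number from compound 2 to compound 4 (0.03 log units; within the scatter) and so stays small, as does the change of chloro to methoxy, which gives a 1.4-fold higher number from compound 1 to compound 4 (0.15 log units; within the scatter) for the same position. Compounds 1, 2 and 4 therefore lie within the scatter of one another, even though the group on this nitrogen carries either chlorine or oxygen. Nothing measured here gives a reason for this. Still open, going by these compounds, is whether a phenyl ring bearing an amine or a carboxylic acid would stay within the scatter too.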